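Swapping Phenyl for Pyridin-2-yl on the Amide Nitrogen

This account rests on a few compounds, and the source may have more. Where it says the series, first, only, none or still open, it means among the compounds named here.

In a functional assay on NCI-H460 cells (Homo sapiens) for inhibition, read by MTT assay, with a stated time of 24 h, tested at 10 ug/mL (a lower number here means less inhibition of growth, a higher number more inhibition of growth at the concentration tested), the measured compounds stand as follows:
Compound 1 `O=C(CCCCC(S)CCS)NO` gives 17.7%
Compound 2 `O=C(CCCCC1CCSS1)Nc1ccccn1` gives "not active" (no number reported)
Compound 3 `O=C(CCCCC(S)CCS)Nc1ccccc1` gives 8.37%

Among the compounds with values here, compound 3 is one of only two compounds with a number. The record shows a number 9.3 percentage points lower from compound 1 to compound 3 (within the scatter) for phenyl in place of hydroxy on an amide-type nitrogen, so compound 3 cannot be separated from compound 1. Compound 4 `O=C(CCCCC(S)CCS)Nc1ccccn1` has not yet been measured and carries pyridin-2-yl in place of phenyl on an amide-type nitrogen. Within the data shown here, no measured step makes this exchange, and the one step above concerns a different group. Compound 2 also carries pyridin-2-yl on an amide-type nitrogen, on a different core, and compound 2 is reported as "not active" (no number reported) in this assay with no number. Neither observation supports a step beyond the scatter, so none is expected. The expected change is a number 0.6 percentage points higher from compound 3 to compound 4 (within the scatter) and no more than that is estimated. Compound 4 is estimated at 9% within an expected range from 2% to 20% in this read-out, though it too may return no number.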

Compound 4, percent growth inhibition at one concentration: "not active" (no number reported)
Nothing numeric was reported for compound 4; there is nothing to compare the estimate with.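

In this assay, within the data shown here, compound 4 gives "not active" (no number reported) and compound 3 gives 8.37% so no step between compound 3 and compound 4 can be read. No evidence bearing on this result is available. The compounds shown leave open whether pyridin-2-yl in place of phenyl on an amide-type nitrogen alters growth inhibition at all.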